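Replacing the Aryl Group on the Amide of Compound 1

The compounds below may be only part of what the source reports. "The series", "measured", "known", "first", "only" and "open" are said of these compounds alone.

For the measured compounds named here, in a functional assay on HUVEC cells (Homo sapiens) for inhibition, with stated times of 2 h and 72 h (a higher number here means a weaker inhibitor, a lower number a stronger inhibitor), compound 1 `COc1cc2nccc(Oc3ccc4c(NC(=O)c5cccc(C(F)(F)F)c5)nn(C)c4c3)c2cc1OC` gives 9 nM, the lowest of the three numbers so far. Compound 3 `COc1cc2nccc(Oc3ccc4c(NC(=O)c5cc(Cl)ccn5)nn(C)c4c3)c2cc1OC` gives 27 nM, and compound 2 `COc1cc2nccc(Oc3ccc4c(NC(=O)c5cc(C(F)(F)F)cc(C(F)(F)F)c5)nn(C)c4c3)c2cc1OC` gives 58 nM. Compound 4 `COc1ccc(C(=O)Nc2nn(C)c3cc(Oc4ccnc5cc(OC)c(OC)cc45)ccc23)cc1` has not yet been measured. It differs from compound 1 by a single change, (4-methoxyphenyl in place of 3-(trifluoromethyl)phenyl on a carbonyl carbon), with 4-methoxyphenyl in place of 3-(trifluoromethyl)phenyl on a carbonyl carbon.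

Going by the values given here, two measured steps bear on this change. Trifluoromethyl in place of hydrogen on an aromatic carbon gave a 6.4-fold higher number from compound 1 to compound 2 (0.81 log units; beyond the scatter). Replacing the same 3-(trifluoromethyl)phenyl with 4-chloropyridin-2-yl on a carbonyl carbon gave a 3.0-fold higher number from compound 1 to compound 3 (0.48 log units; beyond the scatter), and this is the closer comparison. Among the compounds with values here, both steps raised the number beyond the scatter, but no measured compound carries 4-methoxyphenyl on that carbonyl carbon. A modest upward step is therefore expected in this assay, similar in size to the second step. The expected change is a 3.1-fold higher number from compound 1 to compound 4 (0.49 log units; beyond the scatter). For compound 4 the estimated value is 28 nM, with an expected range from 10 nM to 90 nM.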

Compound 4, half-maximal inhibitory concentration: 32 nM
Compound 4: the middle estimate sits 1.1-fold (0.06 log units) below what was measured; the range from low to high includes it.
By their numbers in this assay, from the lowest: compound 1; then compounds 3, 4 and 2 (each within the scatter of the next, the first and the last beyond it).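

In this assay the change to 4-methoxyphenyl gave a 3.6-fold higher number from compound 1 to compound 4 (0.55 log units; beyond the scatter), so a second group on this carbonyl carbon reads above compound 1, this time with a six-membered aromatic ring of carbon only, as in compound 1, rather than the 4-chloropyridin-2-yl of compound 3. Going from that 4-chloropyridin-2-yl to 4-methoxyphenyl gave a 1.2-fold higher number from compound 3 to compound 4 (0.07 log units; within the scatter), so these two different groups cannot be told apart here. Nothing available gives a reason for these differences.

On these data alone, it remains open how a plain phenyl on the same carbonyl carbon would compare with compound 1 and compound 4, which would show what the trifluoromethyl and the methoxy each contribute. Also open, as far as these compounds go, is how an amine or a carboxylic acid on that aryl ring would read in this assay.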